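A few compounds are considered here, and "the series" means these few. Any claim that something is new, unique, unknown or untested is made for them only; others in the source may bear on it.

Working notes on the series. Compound 1 `O=C(Nc1ncc(Cc2ccc(F)cc2)s1)C1CCCCC1` and compound 2 `O=C(Nc1ncc(C(OCc2ccc(Br)cc2)c2ccccc2)s1)c1cccs1` share the same core, and both have been run in an ADME assay on HepG2 2.2.15 cells (Homo sapiens) for cytotoxicity; on this read-out lower numbers stand for higher toxicity in this test and higher numbers for lower toxicity in this test. Compound 1 reaches only the limit of the test there, > 50000 nM, which is a limit and not a number. Compound 2 is recorded in this assay as "not toxic" (no number reported), with no figure attached. Where compound 2 stands on the numbers shown is therefore open: it carries a qualitative call only, next to one further entry that sits at the limit of > 50000 nM in this assay, at which 1 of the 2 values shown sits. Compound 3 `Cc1ccc(COC(c2ccccc2)c2cnc(NC(=O)c3cccs3)s2)cc1` has not yet been measured. It differs from compound 2 in a single place: methyl in place of bromo on an aromatic carbon, in words methyl in place of bromo on an aromatic carbon. Among the measured compounds shown here, no step between measured compounds is available to size the shift, so no change beyond the scatter is assumed in this assay in either direction. Compound 3 is expected to return 50000 nM, with a range from 20000 nM to 100000 nM, most likely again reported only as a limit.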

Compound 3, half-maximal cytotoxic concentration: "not toxic" (no number reported)
No number was reported for compound 3; the estimate stays without a comparison.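

Compound 2 and compound 3 both carry only a "not toxic" call in this assay, with no figure attached, and no step can be read between them. Left open is the size of any shift from bromo to methyl, with compound 1 holding the only entry with a figure, itself a limit: the limit of > 50000 nM in this assay, at which 1 of the 3 values shown sits.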